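The source may report more compounds than this note shows. Statements on the series, on what has been measured and on what is new or still open speak of the compounds shown alone.

Compound 1 `COc1cc[nH]c1/C=C1/C(=O)Nc2ccc(F)cc21` is reported in a functional assay on MDA-MB-435 cells (Homo sapiens) for inhibition (on this read-out higher numbers stand for weaker inhibition and lower numbers for stronger inhibition), only as a limit, > 30000 nM.
Compound 2 `COc1cc[nH]c1/C=C1\C(=O)Nc2ccc(F)c(I)c21` likewise gives only a limit in this assay, > 30000 nM.
Compound 3 `COc1cc[nH]c1/C=C1\C(=O)Nc2ccc(F)c(C#C[C@@H](C)O)c21` gives a number in this assay, 110 nM.

Compound 3 therefore holds the only number shown; the other two results sit at the limit of > 30000 nM in this assay, at which 2 of the 3 values shown sit. Among the compounds with values here, the single measured step, an at least 270-fold lower number from compound 2 to compound 3 (2.43 log units; beyond the scatter), was large and concerns the whole chain entering on the aromatic carbon. Compound 4 `COc1cc[nH]c1/C=C1\C(=O)Nc2ccc(F)c(C#CC(O)CN)c21` differs from compound 3 by 2-amino-1-hydroxyethyl in place of 1-hydroxyethyl on a triple-bonded carbon. Within the data shown here, no measured step touches the far end of that chain, so the step from compound 2 to compound 3 gives no direct guide here. The step of a 1.4-fold higher number from compound 3 to compound 4 (0.13 log units; within the scatter) is expected to stay within the scatter. Compound 4 is estimated at 150 nM, with a range from 40 nM to 600 nM.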

Compound 4, half-maximal inhibitory concentration: 130 nM
The estimate for compound 4 lay 1.2-fold (0.06 log units) above the measured number; low and high end bracket the measured number.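

In this assay, the far end of the chain on the triple-bonded carbon accepts 2-amino-1-hydroxyethyl in place of 1-hydroxyethyl, with a 1.2-fold higher number from compound 3 to compound 4 (0.07 log units; within the scatter), so the two compounds cannot be told apart. The large step away from iodo also holds for this longer chain, with an at least 230-fold lower number from compound 2 to compound 4 (2.36 log units; beyond the scatter). That step is a bound and not an exact size, as compound 2 gives only a limit: the limit of > 30000 nM in this assay, at which 2 of the 4 values shown sit.

The compounds shown leave open whether the hydroxyl group is needed on this chain. They also leave open what a carboxylic acid or a tertiary amine would give in place of the primary amine of compound 4.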